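Replacing thiophen-2-yl in a pair of strong inhibitors

The source may hold more compounds than are shown below. What is called first, only, known or untested is meant among the compounds shown, and "the series" means these compounds.

- compound 1 (`CC(C)(C)Sc1c(CC(C)(C)C(=O)O)n(Cc2ccc(Cl)cc2)c2ccc(OCc3cccc(Cl)n3)cc12`) gives 3 nM
- compound 2 (`CC(C)(C)Sc1c(CC(C)(C)C(=O)O)n(Cc2ccc(Cl)cc2)c2ccc(OCc3cccs3)cc12`) gives 4 nM

Both values come from a functional assay for inhibition, with Homo sapiens as the target (a lower number here means a stronger inhibitor, a higher number a weaker inhibitor), and share the same core. For the measured compounds named here, compound 2 lies within the scatter of compound 1, the only other measured compound, so the two cannot be ranked. Compound 3 (`CC(C)c1csc(COc2ccc3c(c2)c(SC(C)(C)C)c(CC(C)(C)C(=O)O)n3Cc2ccc(Cl)cc2)n1`) keeps that core and changes one group: 4-isopropyl-1,3-thiazol-2-yl in place of thiophen-2-yl on a saturated chain carbon bound to an oxygen on an aromatic ring.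

Going by the values given here, only one measured step bears on this change. It is a 1.3-fold higher number from compound 1 to compound 2 (0.12 log units; within the scatter), and it exchanged 6-chloropyridin-2-yl for thiophen-2-yl at the same place. That exchange left the number within the scatter. It is a single step, however, and neither measured compound carries the 4-isopropyl-1,3-thiazol-2-yl group, so the data offer no direct guide to it. In this assay, a small change of no firm direction is therefore expected, and the range is kept wide. The estimated step is a 1.3-fold higher number from compound 2 to compound 3 (0.10 log units; within the scatter), which is not expected to exceed the scatter. For compound 3 the estimated value is 5 nM, with an expected range from 2 nM to 15 nM.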

Compound 3, half-maximal inhibitory concentration: 3 nM
The estimate for compound 3 lay 1.7-fold (0.22 log units) above the measured number, and the stated range covers the measured number.
By their numbers in this assay, from the lowest: compounds 1, 3 and 2 (each within the scatter of the next).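

In this assay, placing 4-isopropyl-1,3-thiazol-2-yl, with 8 heavy atoms, where thiophen-2-yl had 5 gives a 1.3-fold lower number from compound 2 to compound 3 (0.12 log units; within the scatter) and so adds a branched group and a second ring hetero atom without moving the number beyond the scatter. Set against 6-chloropyridin-2-yl, the same group gives no change at the digits printed from compound 1 to compound 3 (within the scatter), so all three aromatic groups now seen on this saturated chain carbon bound to an oxygen on an aromatic ring give numbers that cannot be ranked. For the compounds shown here, the earlier pair showed this for only two groups, neither of them carrying an isopropyl, whereas the new result shows that this position can hold a noticeably bulkier group in this assay while the number stays within the scatter of the others, though no measured evidence is available to explain this similarity.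

The compounds shown all carry an aromatic ring at this position, which leaves open how a plain alkyl chain, an amine or a carboxylic acid would read here. They also cannot separate the part played by the isopropyl from that of the ring, as the plain 1,3-thiazol-2-yl group is not among them.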